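Adding a Second Methoxy to Compound 1

The source may report more compounds than this note shows. Statements on the series, on what has been measured and on what is new or still open speak of the compounds shown alone.

compound 1 `COc1ccc(/C=C/S(=O)(=O)Cc2ccc(OC)cc2)cc1` > 20000 nM
compound 2 `COc1ccc(CS(=O)(=O)/C=C/c2ccc(F)cc2)cc1` 1500 nM
compound 3 `COc1ccc(CS(=O)(=O)/C=C/c2ccc([N+](=O)[O-])cc2)cc1` 5000 nM

In a functional assay on BT-20 cells (Homo sapiens) for antiproliferative activity, read by trypan blue exclusion (on this read-out higher numbers stand for weaker inhibition and lower numbers for stronger inhibition), compound 1 gives > 20000 nM, which is a limit of the assay and not a number (the limit of > 20000 nM in this assay, at which 1 of the 3 values shown sits). Compound 4 `COc1ccc(CS(=O)(=O)/C=C/c2ccc(OC)c(OC)c2)cc1` differs from compound 1 by methoxy in place of hydrogen on an aromatic carbon. The measured steps replace the methoxy of compound 1 instead of adding to it: an at least 13-fold lower number from compound 1 to compound 2 (1.12 log units; beyond the scatter) and an at least 4.0-fold lower number from compound 1 to compound 3 (0.60 log units; beyond the scatter), while a 3.3-fold higher number from compound 2 to compound 3 (0.52 log units; beyond the scatter). Both changes away from the methoxy lowered the number, yet neither adds a group, so they bear only loosely on compound 4. Compound 4 is therefore expected to stay close to compound 1, with an at least 1.3-fold lower number from compound 1 to compound 4 (0.12 log units; that floor lies within the scatter). In this assay compound 4 is estimated at 15000 nM, between 4000 nM and 40000 nM.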

Compound 4, half-maximal inhibitory concentration: > 20000 nM
Compound 4: only a limit was reported; the forecaster's own chance of this, stated with the estimate: 55%; middle value at least 1.3-fold (0.12 log units) away from the limit.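

In this assay compound 4 gives > 20000 nM, a limit and not a number, and compound 1 also stands at a limit, so no step can be read between compound 1 and compound 4: the limit of > 20000 nM in this assay, at which 2 of the 4 values shown sit.

The compounds shown leave open whether methoxy in place of hydrogen on an aromatic carbon changes the activity of compound 1 at all.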